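The compounds below may be only part of what the source reports. "The series", "measured", "known", "first", "only" and "open" are said of these compounds alone.

Compound 1, with the structure `C=CCn1c(=O)/c(=C\c2ccc(Cl)c(Cl)c2)[nH]c(=O)/c1=C\c1ccccc1OC`, was tested in a functional assay on A549 cells (Homo sapiens) for cytotoxicity, read by CCK-8 assay, with a stated time of 72 h (on this read-out lower numbers stand for stronger inhibition and higher numbers for weaker inhibition), and came back as "not active" (no number reported), so no single number marks where it stands. Among the measured compounds shown here, its close relative compound 2, with the structure `C=CCn1c(=O)/c(=C\c2ccccc2C(F)(F)F)[nH]c(=O)/c1=C\c1ccccc1OC`, gives 7000 nM in this assay, which is the only number in this set. Compound 3, with the structure `C=CCn1c(=O)/c(=C\c2ccc(Cl)c(Cl)c2)[nH]c(=O)/c1=C\c1ccccc1`, has not yet been measured; it differs from compound 1 by hydrogen in place of methoxy on an aromatic carbon. For the measured compounds named here, no measured step covers this change, and with compound 1 giving no number, nothing here says whether the loss of the methoxy moves potency up or down. Weak activity at best is the safer reading, with a fair chance that compound 3 again returns only a limit. Compound 3 is expected to give about 30000 nM, within a range of 8000 nM to 100000 nM.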

Compound 3, half-maximal inhibitory concentration: "not active" (no number reported)
The entry for compound 3 holds no number; no gap can be computed for the estimate.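

In this assay compound 3 gives "not active" (no number reported) and compound 1 gives "not active" (no number reported), so no step can be read between them. The compounds shown leave open how the change from 2-methoxyphenyl to phenyl affects potency. No further evidence bears on this result.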